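From compound 3 to compound 4: a second nitro

The compounds below may be only part of what the source reports. "The series", "measured", "known", "first", "only" and "open" are said of these compounds alone.

In an ADME assay on Vero cells (Chlorocebus sabaeus) for cytotoxicity (on this read-out lower numbers stand for higher toxicity in this test and higher numbers for lower toxicity in this test), compound 3 (`COc1ccc(-c2nc3cc(C(F)(F)F)ccc3[nH]2)c([N+](=O)[O-])c1`) gives 20000 nM. Compound 2 (`COc1cc(-c2nc3cc(C(F)(F)F)ccc3[nH]2)cc(OC)c1OC`) gives 29000 nM, and the two values lie within the scatter of each other. Compound 1 (`COc1ccc(-c2nc3cc(C(F)(F)F)ccc3[nH]2)c(OC)c1`) reaches only a limit of the assay, > 100000 nM. Within the data shown here, the numbers for compound 2 and compound 3 are therefore the only two exact values available in this assay.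

Compound 4 (`O=[N+]([O-])c1ccc(-c2nc3cc(C(F)(F)F)ccc3[nH]2)c([N+](=O)[O-])c1`) has not yet been measured. It departs from compound 3 by one change, (nitro in place of methoxy on an aromatic carbon), which places nitro in place of methoxy on an aromatic carbon, meta to a nitro group and para to a large group.

Among the measured compounds shown here, the only measured swap of this kind is an at least 5.0-fold lower number from compound 1 to compound 3 (0.69 log units; beyond the scatter). That step starts from a limit, so it fixes a minimum size and not an exact one. For the measured compounds named here, with an at least 5.0-fold lower number from compound 1 to compound 3 (0.69 log units; beyond the scatter) as the sole guide, a lower number of broadly similar size is expected, although one step is thin support and the swap here falls at a different place. The estimated move is a 2.9-fold lower number from compound 3 to compound 4 (0.46 log units; beyond the scatter). For compound 4 the expected value is 7000 nM, with an estimated range from 2000 nM to 30000 nM.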

Compound 4, half-maximal cytotoxic concentration: 25000 nM
Beside the measured number, compound 4's estimate is 3.6-fold (0.55 log units) below it; measured number inside the range.
By their numbers in this assay, from the lowest: compounds 3, 4 and 2 (each within the scatter of the next). At a limit, above all of these: compound 1.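

In this assay, nitro in place of methoxy on an aromatic carbon, here meta to a nitro group and para to a large group, gives a 1.3-fold higher number from compound 3 to compound 4 (0.10 log units; within the scatter). Among these compounds, the one earlier swap of the same kind, at a different place on the ring, gave an at least 5.0-fold lower number from compound 1 to compound 3 (0.69 log units; beyond the scatter), so across these two places the same exchange of groups does not come with a single size of step. At this place, with a nitro group already on the ring, the numbers of compound 3 and compound 4 lie within the scatter of each other, and this read-out does not separate methoxy from nitro here.

From the compounds shown here alone, how large the contrast between the two steps really is stays open, because compound 1 sits at a limit of the assay and its step has only a minimum size: the limit of > 100000 nM in this assay, at which 1 of the 4 values shown sits. Also open, going by these compounds, is how an amine or a carboxylic acid in this same place would read in this assay, and whether that reading would depend on the nitro group that stays on the ring.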